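Swapping fluoro for trifluoromethyl on a shared quinazoline-type core

This account rests on a few compounds, and the source may have more. Where it says the series, first, only, none or still open, it means among the compounds named here.

Measured compounds:
- compound 1, `COc1cc2ncnc(Nc3ccc([N+](=O)[O-])cc3)c2c(OC)c1OC`: "not determined" (no result reported)
- compound 2, `COc1cc2ncnc(Nc3ccc(Br)cc3)c2c(OC)c1OC`: 32.6%
- compound 3, `COc1cc2ncnc(Nc3ccc(F)cc3)c2c(OC)c1OC`: "not determined" (no result reported)

All four compounds share one core and differ only in the group on the outer aromatic ring. In a functional assay on BGC-823 cells (Homo sapiens) for inhibition, read by MTT assay, with a stated time of 72 h, tested at 10 uM (a higher number here means more inhibition of growth at the concentration tested, a lower number less inhibition of growth), compound 2 gives 32.6%. For compound 3 the entry in this assay is "not determined" (no result reported), and for compound 1 it is "not determined" (no result reported), so compound 3 cannot be placed against any neighbour. Compound 4, `COc1cc2ncnc(Nc3ccc(C(F)(F)F)cc3)c2c(OC)c1OC`, carries the change (trifluoromethyl in place of fluoro on an aromatic carbon). Among the compounds with values here, with no measured step on this core to lean on, the expected change in this assay from compound 3 to compound 4 is of unknown direction and likely within the scatter. Compound 4 is therefore estimated to give 30%, within a range of 10% to 55%.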

Compound 4, percent growth inhibition at one concentration: 17.4%
Compound 4: the middle estimate sits 12.6 percentage points above what was measured, and the stated range covers the measured number.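

In this assay, within the data shown here, replacing bromo with trifluoromethyl at this position gives a number 15.2 percentage points lower from compound 2 to compound 4 (beyond the scatter), the first readable step on the shared core, and it shows that the choice of group here can alter growth inhibition. The steps involving compound 1 or compound 3 cannot be read, so the fluoro to trifluoromethyl swap itself remains unresolved. No available measurement speaks to the reason for the step. As far as these compounds go, how an amine or a carboxylic acid at this position would compare remains open.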